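The source may report more compounds than this note shows. Statements on the series, on what has been measured and on what is new or still open speak of the compounds shown alone.

Measured compounds:
- compound 1 `Cc1ccc(-c2ncccn2)c(C(=O)N2CCC3(CC3)C[C@H]2CNc2ccc(Cl)cn2)c1`: 7.6
- compound 2 `Cc1ccnc(NC[C@@H]2CC3(CC3)CN2C(=O)c2nc(C)sc2-c2ccccc2)n1`: 6.1
- compound 3 `Cc1ccc(-c2ncccn2)c(C(=O)N2CC3(CC3)C[C@H]2CNc2ccc(Cl)cn2)c1`: 8.2

All three numbers come from a functional assay on CHO cells for antagonist activity at Orexin/Hypocretin receptor type 1 (Homo sapiens), read by FLIPR and calcium flux; a lower number here means a less potent compound, a higher number a more potent compound, by a factor of ten per unit of this negative logarithm. Compound 2 stands lowest of the three; compound 1 is the nearest to it and compound 3 the furthest, and both of those sit higher by margins beyond the usual scatter. Compound 2 shares nothing of its core with compounds 1 and 3, so the two higher numbers say little about what a single change on compound 2 will do.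

The next compound, compound 4 `Cc1cc(C)nc(NC[C@@H]2CC3(CC3)CN2C(=O)c2nc(C)sc2-c2ccccc2)n1`, differs from compound 2 in one place: methyl in place of hydrogen on an aromatic carbon. Within the data shown here, there is no measured pair in this set that isolates that change, so the expected size of the step in this assay rests on the change itself. A second methyl on the 4-methylpyrimidin-2-yl group, giving 4,6-dimethylpyrimidin-2-yl, is expected to move the number only a little, if at all, with a modest gain as the more likely direction; the step from compound 2 to compound 4 is estimated at a number 0.30 log units higher from compound 2 to compound 4 (within the scatter). Compound 4 is therefore expected to give about 6.4 in this assay, within a range from 5.9 to 6.9.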

Compound 4, negative logarithm of the antagonist equilibrium constant: 7.5
Compound 4: the middle estimate sits 1.10 log units below what was measured; measured number above the stated range.
By their numbers in this assay, from the lowest: compound 2; then compounds 4 and 1 (each within the scatter of the next); then compound 3.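

In this assay, changing 4-methylpyrimidin-2-yl to 4,6-dimethylpyrimidin-2-yl gives a number 1.40 log units higher from compound 2 to compound 4 (beyond the scatter): on this aromatic carbon next to the ring nitrogen, a single methyl of one heavy atom makes a large difference. Among these compounds, the earlier compounds held no pair differing in one place; this is the first reading of a single change, and it applies to the core of compound 2 only. Nothing measured among the compounds shown accounts for the size of this step.

Going by these compounds, whether the gain is specific to methyl or extends to other groups on this carbon remains open, and ethyl, methoxy or chlorine there would test it. Also open, on these data alone, is what the existing 4-methyl contributes, which the plain pyrimidin-2-yl group would show.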